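Replacing 3-chlorophenyl with 4-nitrophenyl on an amide-type nitrogen

A few compounds are considered here, and "the series" means these few. Any claim that something is new, unique, unknown or untested is made for them only; others in the source may bear on it.

Compounds measured so far in an ADME assay on MT4 cells (Homo sapiens) for cytotoxicity, read by MTT assay, with a stated time of 5 days; a higher number here means that more compound is tolerated, a lower number that less compound is tolerated:
compound 1 `Cc1cc(OCC(=O)Nc2ccc(Cl)cc2)nc(Nc2ccc(C#N)cc2)n1`: 2630 nM
compound 2 `Cc1cc(OCC(=O)Nc2ccc(Br)cc2)nc(Nc2ccc(C#N)cc2)n1`: 930 nM
compound 3 `Cc1cc(OCC(=O)Nc2cccc(Cl)c2)nc(Nc2ccc(C#N)cc2)n1`: 32200 nM

Among these three, compound 3 has the highest number at 32200 nM. The next compound to be tested is compound 4 `Cc1cc(OCC(=O)Nc2ccc([N+](=O)[O-])cc2)nc(Nc2ccc(C#N)cc2)n1`, which has 4-nitrophenyl in place of 3-chlorophenyl on an amide-type nitrogen.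

Two large steps bear on this change. With 3-chlorophenyl in place of 4-chlorophenyl, the data show a 12-fold higher number from compound 1 to compound 3 (1.09 log units; beyond the scatter). With 3-chlorophenyl in place of 4-bromophenyl, they show a 35-fold higher number from compound 2 to compound 3 (1.54 log units; beyond the scatter). Bromo in place of chloro gave a more modest a 2.8-fold lower number from compound 1 to compound 2 (0.45 log units; beyond the scatter). The 4-nitrophenyl of compound 4 matches the substitution pattern of the 4-chlorophenyl in compound 1 and the 4-bromophenyl in compound 2 , so a large fall from the high number of compound 3 seems likely. Going by the values given here, no nitro compound has been measured, and three compounds are a thin base, so the range stays wide.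

The expected change is an 11-fold lower number from compound 3 to compound 4 (1.03 log units; beyond the scatter). For compound 4 the estimated value is 3000 nM, with an expected range of 700 nM to 15000 nM.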

Compound 4, half-maximal cytotoxic concentration: > 309000 nM
Compound 4: no number, only a limit; the forecaster's own chance of this, stated with the estimate: 5%; middle value at least 100-fold (2.01 log units) away from the limit.
By their numbers in this assay, from the lowest: compound 2; then compound 1; then compound 3. At a limit, above all of these: compound 4.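

In this assay compound 4 gives no number, only a limit of the assay: the limit of > 309000 nM in this assay, at which 1 of the 4 values shown sits.

Among the groups on the amide-type nitrogen, 4-nitrophenyl stands well apart from the two halogen-bearing groups with the same numbering: nitro in place of bromo gives an at least 330-fold higher number from compound 2 to compound 4 (2.52 log units; beyond the scatter), and nitro in place of chloro gives an at least 110-fold higher number from compound 1 to compound 4 (2.07 log units; beyond the scatter). The 3-chlorophenyl group also no longer marks the top of the series, as 4-nitrophenyl in its place gives an at least 9.5-fold higher number from compound 3 to compound 4 (0.98 log units; beyond the scatter), so a change of this one group moves the number across a wide range.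

On these data alone, how far the true value of compound 4 lies beyond its limit stays open, and so does the full size of these steps. As far as these compounds go, it also remains open whether an amine or a carboxylic acid in place of the nitro group would keep the number this high.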